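The source may hold more compounds than are shown below. What is called first, only, known or untested is meant among the compounds shown, and "the series" means these compounds.

For the measured compounds named here, compound 2 `Cc1c(Oc2ccccc2OCCn2ccc(=O)[nH]c2=O)cc(C(C)C)c2ccc(C#N)cc12` is one of only two compounds measured in a toxicity assay on MT2 cells (Homo sapiens) for cytotoxicity, read by MTT assay (a higher number here means that more compound is tolerated, a lower number that less compound is tolerated), where compound 2 gives 9000 nM. Going by the values given here, its sole comparison is compound 1 `CCCc1cc(Oc2ccccc2OCCn2ccc(=O)[nH]c2=O)c(C)c2cc(C#N)ccc12`, which in this assay gives 15000 nM; the step of a 1.7-fold lower number from compound 1 to compound 2 (0.22 log units; within the scatter) stays within the scatter, so the two values cannot be ordered. Compound 3 `Cc1c(Oc2ccccc2OCCn2ccc(=O)[nH]c2=O)cc(CC2CC2)c2ccc(C#N)cc12` differs from compound 2 by cyclopropylmethyl in place of isopropyl on an aromatic carbon. Among the compounds with values here, the one measured step, a small exchange of one saturated group for another on an aromatic carbon, did not move the number, so a comparable step is expected to bring nothing beyond the scatter, no change at the digits printed from compound 2 to compound 3 (within the scatter). Compound 3 is thus estimated at 9000 nM in this assay, between 4000 nM and 20000 nM.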

Compound 3, half-maximal cytotoxic concentration: 13000 nM
For compound 3 the middle estimate is 1.4-fold (0.16 log units) below the measured one, and the stated range covers the measured number.
By their numbers in this assay, from the lowest: compounds 2, 3 and 1 (each within the scatter of the next).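

Placing cyclopropylmethyl instead of isopropyl on this aromatic carbon brings in a three-membered ring, yet this assay gives a 1.4-fold higher number from compound 2 to compound 3 (0.16 log units; within the scatter). The other comparison, a 1.2-fold lower number from compound 1 to compound 3 (0.06 log units; within the scatter), gives the same reading, so propyl, isopropyl and cyclopropylmethyl at this position cannot be told apart in this assay. No measured evidence bears on the reason for this result. On these data alone, all three groups are saturated carbon groups, so it remains open whether an amine, a carboxylic acid or a longer chain at this position would move the number beyond the scatter.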